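Methylation of an aromatic nitrogen in a kinase inhibition screen

The compounds below may be only part of what the source reports. "The series", "measured", "known", "first", "only" and "open" are said of these compounds alone.

Of the compounds shown here, three have so far been measured in an assay on isolated protein for inhibition of Ca2+/calmodulin-dependent protein kinase II (CaM kinase II) (Rattus norvegicus), tested at 30 uM; on this read-out lower numbers stand for less inhibition and higher numbers for more inhibition at the one concentration tested (going by the name of the read-out). Compound 1, `Fc1ccc(Sc2ncnc3[nH]cnc23)cc1`, gives 0% in this assay. Compound 2, `Cn1cnc2c(Sc3ccc(F)cc3)ncnc21`, gives 5% in this assay. The two are related by methyl in place of hydrogen on an aromatic nitrogen, and the resulting step of a number 5 percentage points higher from compound 1 to compound 2 (within the scatter) stays within the scatter of repeated measurements. Compound 3, `c1ccc(CSc2ncnc3[nH]cnc23)cc1`, gives 0% in this assay, the same number as compound 1, and the two compounds sit together at the low end of the three results. The difference between the core of compound 1 and the core of compound 3 is not broken down here.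

Compound 4, `Cn1cnc2c(SCc3ccccc3)ncnc21`, has not yet been measured in this assay. It differs from compound 3 by methyl in place of hydrogen on an aromatic nitrogen, the same change that separates compound 1 from compound 2. The step is therefore expected to be a number 3 percentage points higher from compound 3 to compound 4 (within the scatter), an expectation that rests on the earlier step of a number 5 percentage points higher from compound 1 to compound 2 (within the scatter) and on the value of compound 3, 0%. Compound 4 is accordingly estimated to give about 3% in this assay, with a likely range from -5% to 12%.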

Compound 4, a percentage reported as inhibition, at one concentration (the size of the read-out at that concentration, not a potency): 0%
Beside the measured number, compound 4's estimate is 3 percentage points above it; low and high end bracket the measured number.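

In this assay, methyl in place of hydrogen on an aromatic nitrogen gives no change at the digits printed from compound 3 to compound 4 (within the scatter). Set beside the earlier case, the two steps do not differ by more than repeated measurements of this kind allow: the same change on two cores in this assay, a number 5 percentage points higher (within the scatter) from compound 1 to compound 2 and no change at the digits printed (within the scatter) from compound 3 to compound 4, 5 percentage points apart, within the scatter of two such steps. Within the data shown here, the change thus carries from one core to the other with no step that can be told from scatter on either, but this does not show that the two cores respond alike, nor how the change would behave on a core that gives clear inhibition at the one concentration tested.

The compounds shown leave open whether a longer chain in place of the methyl, or an amine or a carboxylic acid elsewhere on these cores, would give a step beyond the scatter in this assay. They also leave open what the difference between the core of compound 1 and the core of compound 3 contributes on its own.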